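Dropping One Methoxy from a Tetramethoxy Cinnamate Ester

The source may report more compounds than this note shows. Statements on the series, on what has been measured and on what is new or still open speak of the compounds shown alone.

Compound 1, `COc1cc(OC)c(OC)cc1/C=C/COC(=O)/C=C/c1ccc(OC)c(OC)c1`, gives 100%.
Compound 2, `COc1cc(OC)c(OC)cc1/C=C/COC(=O)/C=C/c1cc(OC)c(OC)c(OC)c1OC`, gives 100%.

These two values come from a functional assay on the whole organism (strain Kunming) with Mus musculus as the target, with a stated time of 0.5 h, at a dose of 300 mg/kg by the intraperitoneal route; a higher number here means a weaker effect of the compound at the dose given, a lower number a stronger effect. Compound 2 stands level with compound 1 at the digits shown, and its nearest neighbour in the series is compound 1; the two values lie within the usual scatter of each other, so nothing separates them.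

Compound 3, `COc1cc(OC)c(OC)cc1/C=C/COC(=O)/C=C/c1cc(OC)c(OC)c(OC)c1`, has not yet been measured. It differs from compound 2 in one place: hydrogen in place of methoxy on an aromatic carbon. Nothing in the measured pair gives a reason to expect a step beyond the scatter; both compound 1 and compound 2 sit at the same reading even though they differ in how many methoxy groups the cinnamate ring carries. The step from compound 2 to compound 3 is therefore expected to be no change at the digits printed from compound 2 to compound 3 (within the scatter), that is, none beyond the scatter. Compound 3 is estimated at 100%, within a range from 85% to 100%.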

Compound 3, a percentage reported as activity, at one dose (the size of the read-out at that dose, not a potency): 100%
Compound 3: middle estimate and measured number agree at the digits printed; the range from low to high includes it.
By their numbers in this assay, from the lowest: compounds 1, 2 and 3 (each within the scatter of the next).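

In this assay, hydrogen in place of methoxy on this aromatic carbon, ortho to a large group, gives no change at the digits printed from compound 2 to compound 3 (within the scatter), so the methoxy at this position makes no visible difference to the reading. The other single change, methoxy in place of hydrogen on an aromatic carbon, gives no change at the digits printed from compound 1 to compound 3 (within the scatter), so neither step moves the reading beyond the scatter. No measurement shown here explains why the reading stays level.

Going by these compounds, whether an amine or a carboxylic acid on this aromatic carbon, or a longer chain in place of a methoxy, would shift the reading remains open. With all three compounds level in this assay, these data cannot rank the methoxy patterns against one another.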